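A Larger Group Beside the Hydroxyl of Compound 3

The source may report more compounds than this note shows. Statements on the series, on what has been measured and on what is new or still open speak of the compounds shown alone.

In an in vitro ADME assay on microsomes (Homo sapiens) for metabolic stability (a lower number here means that the compound disappears faster, a higher number that the compound lasts longer), compound 1 `CC(=O)N1CCc2c(C)c3c(n2-c2ccc(C(N)=O)c(c2)N[C@@H](C)[C@H](C)C1)CC(C)(C)CC3=O` gives 0.05 h and compound 2 `Cc1c2c(n3c1CCN(C(=O)C1(N)CC1)C[C@@H](C)[C@H](C)Nc1cc-3ccc1C(N)=O)CC(C)(C)CC2=O` gives 0.0667 h while compound 3 `Cc1c2c(n3c1CCN(C(=O)[C@H](C)O)C[C@@H](C)[C@H](C)Nc1cc-3ccc1C(N)=O)CC(C)(C)CC2=O` gives 0.25 h as the highest of the three numbers. Compound 4 `Cc1c2c(n3c1CCN(C(=O)[C@@H](O)C(C)C)C[C@@H](C)[C@H](C)Nc1cc-3ccc1C(N)=O)CC(C)(C)CC2=O` carries one change from compound 3: isopropyl in place of methyl on a saturated chain carbon bound to a carbonyl carbon and an oxygen on a saturated carbon with isopropyl in place of methyl on a saturated chain carbon bound to a carbonyl carbon and an oxygen on a saturated carbon. The measured steps swap groups on a carbonyl carbon instead: a 5.0-fold higher number from compound 1 to compound 3 (0.70 log units; beyond the scatter) and a 3.7-fold higher number from compound 2 to compound 3 (0.57 log units; beyond the scatter) are modest while a 1.3-fold higher number from compound 1 to compound 2 (0.13 log units; within the scatter) stays within the scatter. None tests this exact swap, so they guide the expectation only loosely. The estimated step of a 1.3-fold lower number from compound 3 to compound 4 (0.10 log units; within the scatter) is expected to stay within the scatter. For compound 4 the estimated half-life is 0.2 h with an expected range from 0.08 h to 0.5 h as its likely span.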

Compound 4, half-life: 0.05 h
Compound 4: the middle estimate sits 4.0-fold (0.60 log units) above what was measured; measured number below the stated range.
By their numbers in this assay, from the lowest: compounds 1, 4 and 2 (each within the scatter of the next); then compound 3.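

At this saturated chain carbon, isopropyl in place of methyl is no neutral swap in this assay, and the half-life falls (a 5.0-fold lower number from compound 3 to compound 4 (0.70 log units; beyond the scatter)). Keeping the hydroxyl does not by itself keep the longer half-life of compound 3: the numbers return to the level of the two compounds without a hydroxyl (no change at the digits printed from compound 1 to compound 4 (within the scatter); a 1.3-fold lower number from compound 2 to compound 4 (0.13 log units; within the scatter)). Nothing measured here explains this drop. With only methyl and isopropyl at this carbon, no trend can be drawn. From the compounds shown here alone, what an ethyl or a cyclopropyl would give there remains open, as does an amine in place of the hydroxyl.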